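The source may hold more compounds than are shown below. What is called first, only, known or untested is meant among the compounds shown, and "the series" means these compounds.

Compound 1, `Cc1ccc(C(/C=C/c2ccc(F)cc2)=N\Nc2nncc3ccccc23)cc1`: 2.4 nM
Compound 2, `Clc1ccc(C(/C=C/c2ccccc2)=N\Nc2nncc3ccccc23)cc1`: 2.3 nM
Compound 3, `O=S(=O)(Nc1ccccn1)c1ccc(Nc2nncc3ccccc23)cc1`: 38 nM

All three were tested in a functional assay on HT-29 cells (Homo sapiens) for antiproliferative activity, read by sulforhodamine B assay, with a stated time of 72 h; on this read-out lower numbers stand for stronger inhibition and higher numbers for weaker inhibition. Compound 2 gives the lowest of the three numbers, but compound 1 sits within the usual scatter of it, so the two cannot be told apart; compound 3 lies beyond the scatter with a higher number. The unmeasured compound 4, `C(=C/c1ccccc1)\C(=N\Nc1nncc2ccccc12)c1ccccc1`, differs from compound 2 in one place: hydrogen in place of chloro on an aromatic carbon. Within the data shown here, no measured pair shows what this change does, so the expectation rests on the general picture: a modest loss is expected, a step of a 2.6-fold higher number from compound 2 to compound 4 (0.42 log units; beyond the scatter) toward a higher number, though one that may still lie within the scatter. Compound 4 is therefore estimated at 6 nM, with a range from 2 nM to 20 nM.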

Compound 4, half-maximal inhibitory concentration: 1.1 nM
Beside the measured number, compound 4's estimate is 5.5-fold (0.74 log units) above it; measured number outside the range, below it.
By their numbers in this assay, from the lowest: compound 4; then compounds 2 and 1 (each within the scatter of the next); then compound 3.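

In this assay hydrogen in place of chloro on this aromatic carbon gives a 2.1-fold lower number from compound 2 to compound 4 (0.32 log units; beyond the scatter) and so shows that the chloro is not needed for a low number here. Among these compounds, the earlier compounds held no pair differing in one place, so this is the first direct reading of this position, and the plain phenyl does at least as well as the 4-chlorophenyl. Nothing available explains the shift. Going by these compounds, whether an amine, a methoxy group or a carboxylic acid at this place would keep the number this low remains open.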